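This account rests on a few compounds, and the source may have more. Where it says the series, first, only, none or still open, it means among the compounds named here.

Working notes on the series, read out in a functional assay on HEK293 cells (Homo sapiens) for cytotoxicity; a higher number here means that more compound is tolerated, a lower number that less compound is tolerated. The shared core is a five-membered non-aromatic ring with one nitrogen, and the three measured compounds differ only in the group on that amide-type nitrogen in a ring. Compound 1 `COc1ccc([C@H]2CC(=O)N(Cc3cccc(C#N)c3)C2)cc1OC1CCCC1` sits at a limit of the assay: in this assay compound 1 gives > 10000 nM. Compound 2 `COc1ccc([C@H]2CC(=O)N(C(=O)c3ccccc3)C2)cc1OC1CCCC1` also reaches only a limit, giving > 10000 nM in this assay. Compound 3 `COc1ccc([C@H]2CC(=O)N(c3cccc(C#N)c3)C2)cc1OC1CCCC1` likewise stops at a limit, with > 10000 nM in this assay. The three steps between them carry no readable size: a step that the two limits leave unreadable from compound 1 to compound 2, a step that the two limits leave unreadable from compound 1 to compound 3 and a step that the two limits leave unreadable from compound 2 to compound 3. Compound 3 therefore stands where every other measured value stands, at the limit of > 10000 nM in this assay, at which 3 of the 3 values shown sit.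

The next compound, compound 4 `COc1ccc([C@H]2CC(=O)N(c3ccc([S+](C)[O-])cc3)C2)cc1OC1CCCC1`, differs from compound 3 at one place: a group of 9 heavy atoms (7 carbon, 1 oxygen, 1 sulfur; one six-membered aromatic ring of carbon only) in place of a group of 8 heavy atoms (7 carbon, 1 nitrogen; one six-membered aromatic ring of carbon only), on an amide-type nitrogen in a ring. Within the data shown here, no measured step bears on this particular exchange beyond the fact that all three exchanges at the same nitrogen, whatever their size, left every compound at the limit. Nothing in the set points to a readable shift, so for compound 4 the step that the limit leaves unreadable from compound 3 to compound 4 is expected to be nothing beyond the scatter and to end, most likely, again at a limit. Compound 4 is thus estimated at 15000 nM, within 5000 nM to 50000 nM.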

Compound 4, half-maximal cytotoxic concentration: 7510 nM
Compound 4: the middle estimate sits 2.0-fold (0.30 log units) above what was measured, within the range that was stated.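

In this assay compound 4 is the only compound shown that gives a number rather than a limit, so the group on the amide-type nitrogen in a ring can bring the read-out off the limit where the others stop: the limit of > 10000 nM in this assay, at which 3 of the 4 values shown sit. Set against those limits, the exchange for the sulfur-bearing group yields floors only: an at least 1.3-fold lower number from compound 3 to compound 4 (0.12 log units; that floor lies within the scatter), an at least 1.3-fold lower number from compound 2 to compound 4 (0.12 log units; that floor lies within the scatter) and an at least 1.3-fold lower number from compound 1 to compound 4 (0.12 log units; that floor lies within the scatter). Each floor lies within the scatter, so a lower number for compound 4 is indicated but no shift beyond the scatter is established, and the steps among compound 1, compound 2 and compound 3 cannot be read.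

The compounds shown leave open how large these steps really are, and whether it is the sulfur and oxygen of the entering group that matter or simply the loss of the nitrile. They also leave open whether a carboxylic acid or an amine on the same aromatic ring would give a number, and whether the sulfur-bearing group would do so when carried on a benzyl or benzoyl linkage to the nitrogen.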